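From Methylamino to a Larger Group on Nitrogen

The compounds below may be only part of what the source reports. "The series", "measured", "known", "first", "only" and "open" are said of these compounds alone.

In a functional assay on G-361 cells (Homo sapiens) for cytotoxicity, read by MTT assay, with a stated time of 3 days (a lower number here means a stronger inhibitor, a higher number a weaker inhibitor), compound 1 `N#Cc1c(O)nc(SCc2nc3ccccc3[nH]2)nc1-c1ccccc1` gives 3.43 nM. Compound 2 `N#Cc1c(Cl)nc(SCc2nc3ccccc3[nH]2)nc1-c1ccccc1` gives 12.5 nM, and compound 3 `CNc1nc(SCc2nc3ccccc3[nH]2)nc(-c2ccccc2)c1C#N` gives 12.5 nM. Compound 3 therefore stands level with compound 2, the pair sharing the highest number of the three. Compound 4 `N#Cc1c(NNC(N)=S)nc(SCc2nc3ccccc3[nH]2)nc1-c1ccccc1` keeps the rest of compound 3 and alters only its methylamino group: a group of 4 heavy atoms (1 carbon, 2 nitrogen, 1 sulfur; no ring) in place of one carbon atom, on a nitrogen on an aromatic ring. For the measured compounds named here, three measured steps bear on this change, though all of them swap groups on an aromatic carbon and none alters the substituent on that nitrogen. Chloro in place of hydroxy gave a 3.6-fold higher number from compound 1 to compound 2 (0.56 log units; beyond the scatter), methylamino in place of hydroxy gave a 3.6-fold higher number from compound 1 to compound 3 (0.56 log units; beyond the scatter), and methylamino in place of chloro gave no change at the digits printed from compound 2 to compound 3 (within the scatter). The series thus offers only modest steps and no guide to direction for a group of this kind, so no shift beyond the scatter is expected. The expected step is a 1.0-fold lower number from compound 3 to compound 4 (0.02 log units; within the scatter). Compound 4 is estimated at 12 nM, with an expected range from 4 nM to 40 nM.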

Compound 4, half-maximal inhibitory concentration: 3.96 nM
Beside the measured number, compound 4's estimate is 3.0-fold (0.48 log units) above it; measured number below the stated range.
By their numbers in this assay, from the lowest: compounds 1 and 4 (each within the scatter of the next); then compounds 2 and 3 (each within the scatter of the next).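

For the compounds shown here, changing the substituent on the nitrogen on an aromatic ring, which no earlier step did, moved the number in this assay: the group of 4 heavy atoms in place of methyl gave a 3.2-fold lower number from compound 3 to compound 4 (0.50 log units; beyond the scatter) and so showed that methylamino does not set the level reached at this position. The step from the chloro compound was of the same printed size, a 3.2-fold lower number from compound 2 to compound 4 (0.50 log units; beyond the scatter), while the step from the hydroxy compound, a 1.2-fold higher number from compound 1 to compound 4 (0.06 log units; within the scatter), places compound 4 within the scatter of compound 1. Nothing measured here explains these steps.

On these data alone, it remains open whether the whole entering group is needed or only part of it, as a plain amino group on that nitrogen would test. An acetyl group or a longer alkyl chain there could show whether compound 4 stands alone or marks a wider trend.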